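From methylamino to arylamino on the shared core

A few compounds are considered here, and "the series" means these few. Any claim that something is new, unique, unknown or untested is made for them only; others in the source may bear on it.

Compound 1 `Cc1nc(NC(=O)C(C)(C)C)sc1-c1nc(N)sc1-n1cc(-c2ccccc2)nn1`: 1500 nM
Compound 2 `CNc1nc(-c2sc(NC(=O)C(C)(C)C)nc2C)c(-n2cc(-c3ccccc3)nn2)s1`: 4900 nM

In an in vitro assay on FRT cells for positive allosteric modulation of Cystic fibrosis transmembrane conductance regulator variant F508del (Homo sapiens), with a stated time of 24 h (a higher number here means that more compound is needed for the effect, a lower number that less compound is needed), compound 1 gives 1500 nM, while compound 2 gives 4900 nM. Among the compounds with values here, compound 2 thus stands at the higher of the two numbers; the one measured step, a 3.3-fold higher number from compound 1 to compound 2 (0.51 log units; beyond the scatter), is modest but beyond the scatter. Compound 3 `COc1ccc(Cl)cc1Nc1nc(-c2sc(NC(=O)C(C)(C)C)nc2C)c(-n2cc(-c3ccccc3)nn2)s1` carries the change (5-chloro-2-methoxyphenyl in place of methyl on a nitrogen on an aromatic ring). Within the data shown here, the only step that bears on it is the methyl-for-hydrogen exchange at the same nitrogen, a 3.3-fold higher number from compound 1 to compound 2 (0.51 log units; beyond the scatter), and that step does not say how a much larger group at this nitrogen will behave. With nothing more to go on, compound 3 is expected to stay close to compound 2, with a step of about a 1.2-fold lower number from compound 2 to compound 3 (0.09 log units; within the scatter), not clearly beyond the scatter in either direction. Compound 3 is therefore estimated at 4000 nM, within a range of 1000 nM to 16000 nM.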

Compound 3, half-maximal effective concentration: 140 nM
The estimate for compound 3 lay 29-fold (1.46 log units) above the measured number; the whole stated range lies above it.
By their numbers in this assay, from the lowest: compound 3; then compound 1; then compound 2.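

Within the data shown here, at the nitrogen on an aromatic ring, the earlier compounds showed only a modest rise on going from hydrogen to methyl, but in this assay the 5-chloro-2-methoxyphenyl group moves the number the other way (a 35-fold lower number from compound 2 to compound 3 (1.54 log units; beyond the scatter)). The number also falls relative to the unsubstituted amine (an 11-fold lower number from compound 1 to compound 3 (1.03 log units; beyond the scatter)), so this much larger group does not continue the direction set by methyl, and compound 3 has the lowest number of the three, with both of its steps beyond the scatter. Nothing available accounts for this reversal. On these data alone, whether the drop belongs to the aromatic ring itself or to its chloro or methoxy group stays open, as compound 3 carries all three together. As far as these compounds go, how a plain phenyl or a benzyl group would read at this nitrogen also remains open.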